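Isatin-derived series: dimethylamino for piperidin-1-yl on the chain

The source may hold more compounds than are shown below. What is called first, only, known or untested is meant among the compounds shown, and "the series" means these compounds.

Measured so far:
compound 1 `Cc1ccc2nc(/N=C3\C(=O)N(CN4CCCCC4)c4ccccc43)sc2c1` — 34500 nM
compound 2 `O=C1C(=O)N(CN(c2ccccc2)c2ccccc2)c2ccccc21` — 24800 nM
compound 3 `O=C1C(=O)N(CN2CCCCC2)c2cccc(Br)c21` — 30200 nM

Three compounds have been run in a functional assay on MDA-MB-231 cells (Homo sapiens) for cytotoxicity, read by sulforhodamine B assay, with a stated time of 48 h; a higher number here means a weaker inhibitor of growth, a lower number a stronger inhibitor of growth. Compound 1 gives 34500 nM, the highest of the three numbers, yet its gap to compound 3 and its gap to compound 2 both sit within the usual scatter of this assay, so no order among the three can be read from these values. All three numbers are weak.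

Compound 4 `Cc1ccc2nc(/N=C3\C(=O)N(CN(C)C)c4ccccc43)sc2c1` has not been measured. It differs from compound 1 in one place: dimethylamino in place of piperidin-1-yl on a saturated chain carbon bound to an amide-type nitrogen in a ring. Among the measured compounds shown here, no pair of measured compounds that differ in exactly one place exists in this set, so no measured step can be used to calibrate this change. With the chain shortened only on the substituent and the shared core of compound 1 left as it is, the change from compound 1 to compound 4 is expected to stay within the scatter, with no direction beyond it: a 1.0-fold higher number from compound 1 to compound 4 (0.01 log units; within the scatter). In this assay compound 4 is therefore estimated at 35000 nM, with a range from 15000 nM to 85000 nM.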

Compound 4, concentration for 50% growth inhibition: 19200 nM
The estimate for compound 4 lay 1.8-fold (0.26 log units) above the measured number, and the stated range covers the measured number.
By their numbers in this assay, from the lowest: compounds 4, 2, 3 and 1 (each within the scatter of the next).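

In this assay the series now has its first pair differing in one place, with a 1.8-fold lower number from compound 1 to compound 4 (0.25 log units; within the scatter) for dimethylamino in place of piperidin-1-yl on a saturated chain carbon bound to an amide-type nitrogen in a ring. On the core of compound 1, therefore, the six-membered non-aromatic ring of the piperidin-1-yl group can give way to an open dimethylamino group without a step beyond the scatter, and this single pair sets no direction for the change. No available evidence accounts for this result.

Still open, as far as these compounds go, is whether morpholin-4-yl, diethylamino or a longer chain carrying the amine would stay equally level at this place. Also open, from the compounds shown here alone, is whether dimethylamino in place of piperidin-1-yl would read the same on the core of compound 3.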